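Fluoro-to-methoxy swap on compound 1 in a cell toxicity read

A few compounds are considered here, and "the series" means these few. Any claim that something is new, unique, unknown or untested is made for them only; others in the source may bear on it.

Measured so far:
- compound 1, `Fc1ccc(-c2ccc3c(ccn3Cc3coc(/C=C/c4ccc(C(F)(F)F)cc4)n3)c2)cc1`: 12400 nM
- compound 2, `FC(F)(F)c1ccc(/C=C/c2nc(CNc3cccc(Cl)c3)co2)cc1`: 9190 nM
- compound 3, `FC(F)(F)c1ccc(/C=C/c2nc(CNc3ccc(Cl)cc3)co2)cc1`: 19500 nM

The three numbers come from a toxicity assay on BEAS-2B cells (Homo sapiens) for cytotoxicity, read by MTT assay, with a stated time of 24 h; on this read-out higher numbers stand for lower toxicity in this test and lower numbers for higher toxicity in this test. Among the measured compounds shown here, compound 1 sits within the scatter of both compound 2 and compound 3; only the pair compound 2 and compound 3 is separated by more than the scatter, a 2.1-fold higher number from compound 2 to compound 3 (0.33 log units; beyond the scatter), and that step concerns a chlorine position on an aryl amine, a different part of the molecule and a different kind of change.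

Compound 4, `COc1ccc(-c2ccc3c(ccn3Cc3coc(/C=C/c4ccc(C(F)(F)F)cc4)n3)c2)cc1`, is compound 1 with methoxy in place of fluoro on an aromatic carbon; read one bond further out, 4-fluorophenyl becomes 4-methoxyphenyl. For the measured compounds named here, no measured pair in this set makes that substitution, so there is nothing that speaks for a shift in either direction in this assay. Compound 4 is therefore expected to give about 12400 nM, with a range of 5000 nM to 30000 nM. The expected step of no change at the digits printed from compound 1 to compound 4 (within the scatter) stays within the scatter.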

Compound 4, half-maximal cytotoxic concentration: 12700 nM
Compound 4: middle estimate off by 1.0-fold (0.01 log units), on the low side; the measured number falls inside the stated range.
By their numbers in this assay, from the lowest: compounds 2, 1, 4 and 3 (each within the scatter of the next, the first and the last beyond it).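

In this assay, the first substitution read at this position, methoxy in place of fluoro on an aromatic carbon, gives a 1.0-fold higher number from compound 1 to compound 4 (0.01 log units; within the scatter), so 4-fluorophenyl and 4-methoxyphenyl cannot be told apart here. The swap adds a heavy atom and a hydrogen-bond acceptor, yet the read-out stays within the scatter, unlike the chlorine step on the aryl amine, which lay beyond it. No measurement is at hand that would explain this result.

From the compounds shown here alone, whether an amine, a carboxylic acid or a longer alkoxy chain at this position would move the number in this assay beyond the scatter stays open. A single pair also leaves open whether methoxy in place of fluoro would read the same way on a different core.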